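Shifting the Pyridyl Attachment on the Shared Core

This account rests on a few compounds, and the source may have more. Where it says the series, first, only, none or still open, it means among the compounds named here.

Three measured compounds share one core. Compound 1 `COc1ccccc1/C=C/C(=O)c1nc2ccccc2[nH]1` gives 7990 nM in a functional assay on HepG2 cells (Homo sapiens) for antiproliferative activity, read by MTT assay, with a stated time of 48 h (on this read-out higher numbers stand for weaker inhibition and lower numbers for stronger inhibition), compound 2 `O=C(/C=C/c1ccccc1)c1nc2ccccc2[nH]1` gives 6300 nM, and compound 3 `O=C(/C=C/c1cccnc1)c1nc2ccccc2[nH]1` gives 8480 nM. Compound 3 holds the highest of the three numbers, yet every gap between it and the others lies within the scatter. Both measured steps were small: a 1.3-fold lower number from compound 1 to compound 2 (0.10 log units; within the scatter) and a 1.3-fold higher number from compound 2 to compound 3 (0.13 log units; within the scatter). Compound 4 `O=C(/C=C/c1ccccn1)c1nc2ccccc2[nH]1` differs from compound 3 by pyridin-2-yl in place of pyridin-3-yl on a double-bonded chain carbon bound to a double-bonded chain carbon. Among the compounds with values here, no measured step rearranges the ring nitrogen in this way; the nearest guide is the change that produced compound 3 from compound 2, which stayed within the scatter, so no shift beyond the scatter in this assay is expected. Compound 4 is therefore estimated at 8000 nM, within 3500 nM to 18000 nM. This corresponds to an expected 1.1-fold lower number from compound 3 to compound 4 (0.03 log units; within the scatter).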

Compound 4, half-maximal inhibitory concentration: 340 nM
Estimate against measurement, compound 4: 24-fold (1.37 log units) above, and the stated range ends above it.
By their numbers in this assay, from the lowest: compound 4; then compounds 2, 1 and 3 (each within the scatter of the next).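

Within the data shown here, replacing pyridin-3-yl with pyridin-2-yl keeps the same atoms and the same counts, yet in this assay it gives a 25-fold lower number from compound 3 to compound 4 (1.40 log units; beyond the scatter), so at this place the way the pyridine ring is attached matters far more than the earlier steps suggested. Pyridin-2-yl also separates clearly from phenyl, with a 19-fold lower number from compound 2 to compound 4 (1.27 log units; beyond the scatter), whereas pyridin-3-yl stayed within the scatter of phenyl, so among these compounds a pyridine ring alone does not bring the lower number. No evidence on hand gives a reason for this difference. The compounds shown leave open how pyridin-4-yl would behave at this place, and whether a methoxy group on the pyridin-2-yl ring would keep the low number.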